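A few compounds are considered here, and "the series" means these few. Any claim that something is new, unique, unknown or untested is made for them only; others in the source may bear on it.

Compound 1 `O=[N+]([O-])c1c(CS(=O)(=O)c2ccccc2)nc2c(C#Cc3ccccc3)cc(Cl)cn12` gives, as a limit of the assay and not a number, > 3900 nM in an ADME assay on HepG2 cells (Homo sapiens) for cytotoxicity, read by MTT assay, with a stated time of 72 h; on this read-out higher numbers stand for lower toxicity in this test and lower numbers for higher toxicity in this test.
Compound 2 `COc1cccc(C#Cc2cc(Cl)cn3c([N+](=O)[O-])c(CS(=O)(=O)c4ccccc4)nc23)c1` gives in this assay a limit, > 3900 nM.
Compound 3 `O=[N+]([O-])c1c(CS(=O)(=O)c2ccccc2)nc2c(C#Cc3ccc(CO)cc3)cc(Cl)cn12` gives in this assay a limit, > 15600 nM.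

Compound 2 therefore stands only at a limit in this assay, and the two further values shown are limits as well: two of the three sit at the limit of > 3900 nM in this assay, at which 2 of the 3 values shown sit, and one at the limit of > 15600 nM in this assay, at which 1 of the 3 values shown sits. Compound 4 `O=[N+]([O-])c1c(CS(=O)(=O)c2ccccc2)nc2c(C#CC3(O)CCCCC3)cc(Cl)cn12` differs from compound 2 by 1-hydroxycyclohexyl in place of 3-methoxyphenyl on a triple-bonded carbon. The steps measured so far bear on this change only in outline: a step that the two limits leave unreadable from compound 1 to compound 2, a step that the two limits leave unreadable from compound 1 to compound 3 and a step that the two limits leave unreadable from compound 2 to compound 3 all leave their size unreadable, since both ends are limits. No step beyond the usual scatter can thus be expected in this assay in either direction from the evidence at hand, and the step that the limit leaves unreadable from compound 2 to compound 4 is an estimate resting on that. Compound 4 is expected to give 8000 nM in this assay, within 3000 nM to 30000 nM, most probably reported again only as a limit.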

Compound 4, half-maximal cytotoxic concentration: > 25000 nM
Compound 4 gave a limit, no number; the forecaster's own chance of this, stated with the estimate: 80%; middle value at least 3.1-fold (0.49 log units) from the limit.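

Compound 4, like compound 1, compound 2 and compound 3, stands only at a limit, so none of the steps joining compound 4 to those three can be read. The compounds shown leave open how far any change on the triple-bonded carbon moves the half-maximal cytotoxic concentration in this assay.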